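Methoxy for methyl, meta this time, in lipophilicity

The compounds below may be only part of what the source reports. "The series", "measured", "known", "first", "only" and "open" are said of these compounds alone.

Measured so far:
Compound 1, `C=CCc1ccc(OC(=O)c2ccc(OC)cc2)c(OC)c1`, gives 1.86 in a physicochemical assay for lipophilicity; a lower number here means a more polar compound, a higher number a more lipophilic compound.
Compound 2, `C=CCc1ccc(OC(=O)c2ccc(C)cc2)c(OC)c1`, gives 2.87 in this assay.
Compound 3, `C=CCc1ccc(OC(=O)c2cccc(C)c2)c(OC)c1`, gives 2.87 in this assay.

Compound 3 differs from compound 2 only in how the same atoms are joined: 3-methylphenyl in place of 4-methylphenyl on a carbonyl carbon. In this assay this gives no change at the digits printed from compound 2 to compound 3 (within the scatter), so the two stand level, together the highest of the three numbers. Compound 1 differs from compound 2 by methoxy in place of methyl on an aromatic carbon, and this change made a number 1.01 log units lower from compound 2 to compound 1 (beyond the scatter).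

Compound 4, `C=CCc1ccc(OC(=O)c2cccc(OC)c2)c(OC)c1`, has not yet been measured in this assay. It differs from compound 3 by methoxy in place of methyl on an aromatic carbon. This is the same kind of change as that from compound 2 to compound 1, but not the same: there the methoxy entered para to a large group, here it enters meta to a large group. For the measured compounds named here, only one measured instance of this change is available, so the expectation rests on it alone. The account expects a step of a number 0.92 log units lower from compound 3 to compound 4 (beyond the scatter), resting on the step of a number 1.01 log units lower from compound 2 to compound 1 (beyond the scatter), with the difference in place leaving room for the step to come out somewhat smaller or larger. For compound 4 the estimate is 1.95, with a range from 1.6 to 2.35.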

Compound 4, partition coefficient: 1.86
Compound 4: the middle estimate sits 0.09 log units above what was measured, within the range that was stated.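

In this assay, methoxy in place of methyl on an aromatic carbon, here meta to a large group, gave a number 1.01 log units lower from compound 3 to compound 4 (beyond the scatter) and so matched at the digits printed the earlier instance of the same change, which gave a number 1.01 log units lower from compound 2 to compound 1 (beyond the scatter) on the same shared core. This shows that within this small set the change carried over between two placements on one aromatic ring with no difference in size at the digits printed, so the two steps now agree, but it rests on two instances alone and does not show that the same step would appear on a different core or on another ring of this one. Nothing among the data shown accounts for the size of the step or for its sameness at the two places.

The compounds shown leave open whether another group in the same place, such as an amine, a carboxylic acid or a longer chain like ethoxy, would move the number by a comparable amount. They also leave open whether the methoxy for methyl step would keep this size once the rest of the core is altered, for instance with the carbonyl replaced by another linking group.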